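Replacing nitro with ethoxycarbonyl in a level series

The source may hold more compounds than are shown below. What is called first, only, known or untested is meant among the compounds shown, and "the series" means these compounds.

Of the compounds shown here, three sharing one core have been tested in a functional assay (Homo sapiens); on this read-out higher numbers stand for weaker inhibition and lower numbers for stronger inhibition. There, compound 1 `Nc1nc2ccnc(-c3cccc(OC(F)F)c3)n2n1` gives 3400 nM; 3400 nM (2 entries), compound 2 `Nc1nc2ccnc(-c3cccc(Br)c3)n2n1` gives 3700 nM; 3700 nM (2 entries), and compound 3 `Nc1nc2ccnc(-c3cccc([N+](=O)[O-])c3)n2n1` gives 3800 nM. Compound 3 therefore stands level with the other two: all three values lie within the usual scatter of repeated measurements, so no ranking can be read from them.

The next compound, compound 4 `CCOC(=O)c1cccc(-c2nccc3nc(N)nn23)c1`, carries ethoxycarbonyl in place of nitro on an aromatic carbon, meta to a large group: ethoxycarbonyl in place of nitro on an aromatic carbon. For the measured compounds named here, no measured pair differs in one place only, so the data give no direct size for such a step. Going by the values given here, the only guide is that compound 3 at 3800 nM sits level with two compounds bearing other groups. In this assay, the expectation is therefore no shift beyond the scatter, in either direction. The expected change is a 1.1-fold higher number from compound 3 to compound 4 (0.02 log units; within the scatter). For compound 4 the estimated value is 4000 nM, with an expected range of 1800 nM to 9000 nM.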

Compound 4, half-maximal inhibitory concentration: 11500 nM
Compound 4: middle estimate off by 2.9-fold (0.46 log units), on the low side; measured number outside the range, above it.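

In this assay, replacing nitro with ethoxycarbonyl gives a 3.0-fold higher number from compound 3 to compound 4 (0.48 log units; beyond the scatter), a step beyond the usual scatter and a sign of weaker inhibition. For the compounds shown here, this shows that the group at this position, on the aromatic ring and meta to a large group, can change the read-out, which the level values of the earlier compounds could not reveal. The entering group has 5 heavy atoms against 3 for nitro, with the same counts of hydrogen-bond donors and acceptors, but no measurement here explains why the number rises.

From the compounds shown here alone, it remains open whether this step follows from the ester as a whole or from its ethyl part. A methoxycarbonyl group, a carboxylic acid or a primary amide at the same place would help separate these possibilities.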